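A Tetrazolylbenzyl Thiourea Analogue Awaiting Measurement

The source may report more compounds than this note shows. Statements on the series, on what has been measured and on what is new or still open speak of the compounds shown alone.

Compound 1 `CC1=C(C(=O)OCc2ccccc2)C(c2ccc(-c3ccccc3C)cc2)NC(=O)N1Cc1ccc(-c2nnn[nH]2)cc1`: 140000 nM in a toxicity assay on MCF7 cells (Homo sapiens) for inhibition, with a stated time of 48 h; a lower number here means a stronger inhibitor of growth, a higher number a weaker inhibitor of growth
Compound 2 `CC1=C(C(=O)OCc2ccccc2)C(c2ccc(-c3ccccc3)cc2)N(CCCCCC(=O)O)C(=S)N1`: "not determined" (no result reported) in this assay

Compound 2 stands nowhere on the numbers shown: in this assay compound 2 has only "not determined" (no result reported) and no value, so the thiourea core bearing the acid chain has no anchor of its own. Compound 3 `CC1=C(C(=O)OCc2ccccc2)C(c2ccc(-c3ccccc3)cc2)N(Cc2ccc(-c3nnn[nH]3)cc2)C(=S)N1` differs from compound 2 in one place: 4-(1H-tetrazol-5-yl)phenyl in place of 4-carboxybutyl on a saturated chain carbon bound to an amide-type nitrogen in a ring. For the measured compounds named here, no step between measured compounds is available, so neither the size nor the direction of this change can be read from the data, and no step size is assigned to it here. Going by the values given here, the only compound with a number is compound 1, and in this assay compound 1 gives 140000 nM, a weak result on a closely related core. Compound 3 is therefore expected to land in a similarly weak region, estimated at 100000 nM, with a range from 30000 nM to 300000 nM.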

Compound 3, concentration for 50% growth inhibition: 110000 nM
The estimate for compound 3 lay 1.1-fold (0.04 log units) below the measured number; the range from low to high includes it.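

No new step can be read from compound 3: compound 2, its one-place neighbour, has no number in this assay to compare, and compound 1 differs from it in more than one place. The compounds shown leave open what exchanging 5-carboxypentyl for 4-(1H-tetrazol-5-yl)benzyl does to growth inhibition. No evidence bearing on this result is available.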